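This account rests on a few compounds, and the source may have more. Where it says the series, first, only, none or still open, it means among the compounds named here.

Compound 1 `CN(C(=O)NC(=O)c1ccccc1F)c1nc(C(F)(F)F)c(C(=O)N/N=C/c2cc(C(F)(F)F)cc(C(F)(F)F)c2)s1` was tested in a functional assay on MCF7 cells (Homo sapiens) for inhibition, read by MTT assay, with a stated time of 72 h (a lower number here means a stronger inhibitor, a higher number a weaker inhibitor), where compound 1 gives 6.16 ug/mL. Among the three measured compounds this is the largest number, but the gap to compound 3 `CN(C(=O)NC(=O)c1cccc(C(F)(F)F)c1)c1nc(C(F)(F)F)c(C(=O)N/N=C/c2cc(C(F)(F)F)cc(C(F)(F)F)c2)s1`, which gives 6.08 ug/mL, is small: a 1.0-fold lower number from compound 1 to compound 3 (0.01 log units; within the scatter). Compound 2 `CN(C(=O)NC(=O)c1ccc(F)c(F)c1)c1nc(C(F)(F)F)c(C(=O)N/N=C/c2cc(C(F)(F)F)cc(C(F)(F)F)c2)s1` gives 2.61 ug/mL, and a 2.4-fold lower number from compound 1 to compound 2 (0.37 log units; beyond the scatter); likewise a 2.3-fold higher number from compound 2 to compound 3 (0.37 log units; beyond the scatter).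

Compound 4 `CN(C(=O)NC(=O)c1ccccc1F)c1nc(C(F)(F)F)c(C(=O)N/N=C/c2cccc(C(F)(F)F)c2)s1` differs from compound 1 by hydrogen in place of trifluoromethyl on an aromatic carbon. Every measured step instead exchanges the aryl group on the carbonyl carbon, so none of them touches the position altered here, and those steps were at most modest. Going by the values given here, with no directly relevant precedent, compound 4 is expected to show a 1.1-fold higher number from compound 1 to compound 4 (0.02 log units; within the scatter), a change not beyond the scatter. Compound 4 is therefore estimated at 6.5 ug/mL, with a range from 3 ug/mL to 14 ug/mL.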

Compound 4, half-maximal inhibitory concentration: 20.5 ug/mL
Beside the measured number, compound 4's estimate is 3.2-fold (0.50 log units) below it; the whole stated range lies below it.
By their numbers in this assay, from the lowest: compound 2; then compounds 3 and 1 (each within the scatter of the next); then compound 4.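

Measured in this assay the exchange of this trifluoromethyl for hydrogen gives a 3.3-fold higher number from compound 1 to compound 4 (0.52 log units; beyond the scatter) and so a weaker inhibitor. Going by these compounds alone, the earlier compounds varied only the aryl group on the carbonyl carbon, so this is the first sign that the number also responds to a change on the other six-membered aromatic ring. Nothing measured here explains the shift. As far as these compounds go, it remains open whether a smaller group such as methyl or chlorine at this carbon would keep the number of compound 1. Also open, from the compounds shown here alone, is whether the same exchange would have a similar effect alongside the 3,4-difluorophenyl of compound 2.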